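Benzyl extension on the acetyl arm: cytotoxicity expectation

A few compounds are considered here, and "the series" means these few. Any claim that something is new, unique, unknown or untested is made for them only; others in the source may bear on it.

Two members of the series have been run in an ADME assay on L929 cells (Mus musculus) for cytotoxicity, read by resazurin assay, with a stated time of 72 h; on this read-out lower numbers stand for stronger inhibition and higher numbers for weaker inhibition. Compound 1 `OB1OCc2ccc(-n3cc(Sc4ccc(Cl)c(Cl)c4)c4ccccc43)cc21` reaches only the limit of the assay there, giving > 10 ug/mL. Compound 2 `CC(=O)c1ccn(-c2ccc3c(c2)B(O)OC3)c1` likewise stops at a limit in this assay, giving > 10 ug/mL. So compound 2 stands with the whole measured set at the limit of > 10 ug/mL in this assay, at which 2 of the 2 values shown sit; no number places it relative to compound 1, and no step between measured compounds is available.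

Compound 3 `O=C(CCc1ccccc1)c1ccn(-c2ccc3c(c2)B(O)OC3)c1` is the next candidate for this assay. It differs from compound 2 by benzyl in place of hydrogen on a saturated chain carbon bound to a carbonyl carbon.

Going by the values given here, with both measured values sitting at a limit, there is no measured step on which to lean. The expected change from compound 2 to compound 3 in this assay is a step that the limit leaves unreadable from compound 2 to compound 3, that is, none beyond the scatter or at most a modest move toward stronger inhibition. Compound 3 is estimated at 15 ug/mL, with a range from 5 ug/mL to 40 ug/mL, and a reported limit rather than a number remains the more likely outcome.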

Compound 3, half-maximal inhibitory concentration: > 10 ug/mL
Compound 3 gave a limit, no number (the forecaster's own chance of this, stated with the estimate: 65%); the middle value does not contradict the limit.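

No step can be read between compound 2 and compound 3, as both stop at a limit in this assay. The compounds shown leave open whether the benzyl extension shifts cytotoxicity at all, since the whole set stands at one value: the limit of > 10 ug/mL in this assay, at which 3 of the 3 values shown sit.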